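The compounds below may be only part of what the source reports. "The series", "measured", "known", "first", "only" and "open" are said of these compounds alone.

Compound 1 `Cc1cccc(/C(N)=N/NC(=S)N2CCSCC2)n1` and compound 2 `N/C(=N\NC(=S)N1CCSCC1)c1ccccn1` share the same core and differ only in one small group. In a functional assay on A-431 cells (Homo sapiens) for cytotoxicity, read by MTT assay, with a stated time of 72 h, tested at 3 uM (a higher number here means more inhibition of growth at the concentration tested, a lower number less inhibition of growth), compound 1 gives 51.7%, and compound 2 gives 37.2%. Compound 1 therefore stands highest of the two numbers; the step of a number 14.5 percentage points lower from compound 1 to compound 2 (beyond the scatter) goes with hydrogen in place of methyl on an aromatic carbon, a change beyond the scatter. Compound 3 `Cc1cccc(/C(N)=N/NC(=S)N2CCCC2)n1` differs from compound 1 in another place: pyrrolidin-1-yl in place of thiomorpholin-4-yl on a thiocarbonyl carbon. Going by the values given here, no measured step touches the thiocarbonyl carbon, and the single measured step concerns a different part of the molecule, so it offers no guide to the direction of this change. On that basis a step within the scatter is expected, a number 1.7 percentage points lower from compound 1 to compound 3 (within the scatter). Compound 3 is estimated to give 50% in this assay, with a range from 30% to 70%.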

Compound 3, percent growth inhibition at one concentration: 47.2%
For compound 3 the middle estimate is 2.8 percentage points above the measured one; low and high end bracket the measured number.
By their numbers in this assay, from the lowest: compounds 2, 3 and 1 (each within the scatter of the next, the first and the last beyond it).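

In this assay, putting pyrrolidin-1-yl in place of thiomorpholin-4-yl on the thiocarbonyl carbon gives a number 4.5 percentage points lower from compound 1 to compound 3 (within the scatter). Going by these compounds alone, this is the first look at this position, and it shows that in this pair the ring can lose its sulfur and shrink from six-membered to five-membered without a step that stands out from the scatter, unlike the earlier step at the aromatic carbon. Nothing measured here bears on why the two rings read alike.

The compounds shown leave open whether a morpholin-4-yl ring, a piperazin-1-yl ring or an open-chain diethylamino group on the same carbon would also stay within the scatter. They also leave open how pyrrolidin-1-yl behaves when hydrogen replaces the methyl on the aromatic carbon.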